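A few compounds are considered here, and "the series" means these few. Any claim that something is new, unique, unknown or untested is made for them only; others in the source may bear on it.

Compound 1, `COc1cc(-c2ccnc3cc(-c4ccc(Cl)cc4)nn23)cc(OC)c1OC`, stands at the top of the three measured numbers in a functional assay on A549 cells (Homo sapiens) for inhibition, read by CCK-8 assay, with a stated time of 48 h; on this read-out lower numbers stand for stronger inhibition and higher numbers for weaker inhibition: compound 1 gives 3070 nM, while compound 2, `COc1cc(-c2ccnc3cc(-c4ccc5cc[nH]c5c4)nn23)cc(OC)c1OC`, gives 170 nM and compound 3, `COc1cc(-c2ccnc3cc(-c4c[nH]c5ccccc45)nn23)cc(OC)c1OC`, gives 29 nM. The step of an 18-fold lower number from compound 1 to compound 2 (1.26 log units; beyond the scatter) and the step of a 110-fold lower number from compound 1 to compound 3 (2.02 log units; beyond the scatter) both replace the whole 4-chlorophenyl group with an indolyl group, and the step of a 5.9-fold lower number from compound 2 to compound 3 (0.77 log units; beyond the scatter) separates the two indolyl attachments.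

Compound 4, `COc1cc(-c2ccnc3cc(-c4ccc(-c5cnn(C)c5)cc4)nn23)cc(OC)c1OC`, keeps the phenyl ring of compound 1 and alters only its substituent: 1-methyl-1H-pyrazol-4-yl in place of chloro on an aromatic carbon. Among the compounds with values here, no measured step replaces the chloro alone, so the two large steps from compound 1 show only that a change at this part of the shared core can lower the number considerably; they do not show what a 1-methyl-1H-pyrazol-4-yl in place of chloro does. He therefore expects a modest step downward in this assay, a 2.0-fold lower number from compound 1 to compound 4 (0.31 log units; beyond the scatter), with wide uncertainty. His estimate for compound 4 in this assay is 1500 nM, within the range 400 nM to 5000 nM.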

Compound 4, half-maximal inhibitory concentration: 1150 nM
For compound 4 the middle estimate is 1.3-fold (0.12 log units) above the measured one; measured number inside the range.
By their numbers in this assay, from the lowest: compound 3; then compound 2; then compound 4; then compound 1.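

Within the data shown here, with the phenyl ring kept, the earlier steps' replacement of the whole ring gives way to a change in the substituent alone: in this assay, 1-methyl-1H-pyrazol-4-yl in place of chloro, para to a large group, gives a 2.7-fold lower number from compound 1 to compound 4 (0.43 log units; beyond the scatter). This shows that the number does not rise when the single chlorine at this place gives way to a much larger group carrying a five-membered aromatic ring, and that the number can fall without either indolyl group. Nothing given here explains why this change lowers the number.

The compounds shown leave open whether the methyl on the pyrazole ring contributes to this step. They also leave open how an amine, a carboxylic acid or a morpholine ring at the same place would compare with chloro.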